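Biaryl amide variation: compound 4 against compound 1

A few compounds are considered here, and "the series" means these few. Any claim that something is new, unique, unknown or untested is made for them only; others in the source may bear on it.

Measured so far:
compound 1 `COC(=O)C(Cc1cccc(C(=N)N)c1)C(/C=C/c1ccccc1)NC(=O)c1ccc(-c2ccccc2C)cc1`: 3100 nM
compound 2 `COC(=O)C(Cc1cccc(C(=N)N)c1)C(/C=C/c1ccccc1)NC(=O)c1ccc(-c2ccccc2OC)cc1`: 1800 nM
compound 3 `COC(=O)C(Cc1cccc(C(=N)N)c1)C(/C=C/c1ccccc1)NC(=O)c1ccc(-c2ccc(OC)cc2OC)cc1`: 2900 nM

In an assay on isolated protein (Oryctolagus cuniculus) for inhibition of Trypsin (Homo sapiens) (on this read-out higher numbers stand for weaker inhibition and lower numbers for stronger inhibition), compound 1 has the highest of the three numbers, yet compound 3 and compound 2 both sit within the scatter of it. The steps of a 1.7-fold lower number from compound 1 to compound 2 (0.24 log units; within the scatter) and a 1.1-fold lower number from compound 1 to compound 3 (0.03 log units; within the scatter) alter the 2-methylphenyl group of compound 1 and neither leaves the scatter; a 1.6-fold higher number from compound 2 to compound 3 (0.21 log units; within the scatter) does not either. Compound 4 `CCOc1ccc(-c2ccc(C(=O)NC(/C=C/c3ccccc3)C(Cc3cccc(C(=N)N)c3)C(=O)OC)cc2)cc1` differs from compound 1 by 4-ethoxyphenyl in place of 2-methylphenyl on an aromatic carbon. Going by the values given here, no measured step puts a group para to a large group on that ring, so the only guidance is that all three measured variants of this group lie close together. A step of a 1.2-fold lower number from compound 1 to compound 4 (0.09 log units; within the scatter) is therefore expected, within the scatter. For compound 4 a value of 2500 nM is estimated, in the range 1000 nM to 6500 nM.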

Compound 4, half-maximal inhibitory concentration: 2800 nM
Compound 4: the middle estimate sits 1.1-fold (0.05 log units) below what was measured; the range from low to high includes it.
By their numbers in this assay, from the lowest: compounds 2, 4, 3 and 1 (each within the scatter of the next).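

Going by these compounds alone, replacing the substituted phenyl groups of the earlier compounds with 4-ethoxyphenyl gives a 1.1-fold lower number from compound 1 to compound 4 (0.04 log units; within the scatter) and a 1.0-fold lower number from compound 3 to compound 4 (0.02 log units; within the scatter) and a 1.6-fold higher number from compound 2 to compound 4 (0.19 log units; within the scatter) in this assay with every step inside the scatter. A group para to a large group therefore holds the same level of inhibition as 2-methylphenyl and 2-methoxyphenyl. No measurement at hand accounts for this flat response.

Open, from the compounds shown here alone, is whether an amine, a carboxylic acid or a longer ether chain on this ring would move the number beyond the scatter. Also open, going by these compounds, is whether the flat response holds when the rest of the core changes.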